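This account rests on a few compounds, and the source may have more. Where it says the series, first, only, none or still open, it means among the compounds named here.

Measured compounds:
compound 1 `CCOC(=O)c1c(-c2ccc(F)cc2)oc2ccc(OCCN3C(=O)C(=O)c4ccccc43)cc12` gives 128000 nM in an ADME assay on CHO cells (Cricetulus griseus) for cytotoxicity, read by MTT assay, with a stated time of 72 h; a higher number here means that more compound is tolerated, a lower number that less compound is tolerated;
compound 2 `CCOC(=O)c1c(-c2ccc(F)cc2)oc2ccc(OCCN3C(=O)C(=O)c4cc(OC)ccc43)cc12` gives 512000 nM in this assay;
compound 3 `CCOC(=O)c1c(-c2ccccc2)oc2ccc(OCCCN3C(=O)C(=O)c4ccccc43)cc12` gives 256000 nM in this assay.

Compound 4 `CCOC(=O)c1c(-c2ccccc2)oc2ccc(OCCCN3C(=O)C(=O)c4cc(OC)ccc43)cc12` has not yet been measured in this assay. It is related to compound 3 in the same way that compound 2 is related to compound 1. The change from compound 1 to compound 2 is methoxy in place of hydrogen on an aromatic carbon and it produced a 4.0-fold higher number from compound 1 to compound 2 (0.60 log units; beyond the scatter). The change from compound 3 to compound 4 is methoxy in place of hydrogen on an aromatic carbon; its place description agrees word for word with that of the earlier change, so it is the same change made on a different core. The difference between the core of compound 1 and the core of compound 3 is not broken down here. What the two values show is that compound 1 and compound 3 lie within the scatter of each other in this assay, as do compound 3 and compound 2.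

Within the data shown here, since the only measured example of this change, from compound 1 to compound 2, gave a 4.0-fold higher number from compound 1 to compound 2 (0.60 log units; beyond the scatter), compound 4 is expected to show a step of about a 2.7-fold higher number from compound 3 to compound 4 (0.44 log units; beyond the scatter) in this assay, because the starting point of compound 3 is 256000 nM and the change is identical. That expectation rests on a single pair, so it is held loosely. Compound 4 is therefore estimated at 700000 nM in this assay, with a range from 250000 nM to 2000000 nM.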

Compound 4, half-maximal cytotoxic concentration: 512000 nM
Estimate against measurement, compound 4: 1.4-fold (0.14 log units) above; low and high end bracket the measured number.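

Set side by side in this assay, the two readings of methoxy in place of hydrogen on an aromatic carbon cannot be told apart: the same change on two cores in this assay, a 4.0-fold higher number (0.60 log units; beyond the scatter) from compound 1 to compound 2 and a 2.0-fold higher number (0.30 log units; within the scatter) from compound 3 to compound 4, 2.0-fold (0.30 log units) apart, within the scatter of two such steps. The series therefore gives no sign that this change behaves differently on the second core, although the new step, a 2.0-fold higher number from compound 3 to compound 4 (0.30 log units; within the scatter), is on its own too small to be separated from repeat measurement, whereas the earlier step, a 4.0-fold higher number from compound 1 to compound 2 (0.60 log units; beyond the scatter), is not. This shows agreement between two cores only: it does not establish that methoxy reliably gives a higher number wherever it is placed on a new core, and the pair on the second core, taken alone, shows no real separation.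

The compounds shown leave open how a chlorine atom, a hydroxyl group or an amine would read in the same place on the aromatic carbon, and so whether the result is particular to methoxy. They also leave open whether the step would hold on a core with a longer chain, or on one with a carboxylic acid in place of the ethyl ester.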